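From Fluoro to Methyl: Estimating Compound 4

The source may report more compounds than this note shows. Statements on the series, on what has been measured and on what is new or still open speak of the compounds shown alone.

Of the compounds shown here, three have been measured in an assay on cells for inhibition of Palmitoleoyl-protein carboxylesterase NOTUM variant C330S (Homo sapiens), read by fluorescence, with a stated time of 40 min; a higher number here means a weaker inhibitor, a lower number a stronger inhibitor. Compound 1 `O=C(O)C1CCN(c2ccccc2)C1` gives 48000 nM, compound 2 `Cc1c[nH]c(C)c1C(=O)O` gives 100000 nM, and compound 3 `Cc1cc(C(=O)O)c(C)n1-c1ccc(F)cc1` gives 1900 nM in this assay. Compound 3 thus stands lowest of the three, and its gap to compound 1 and to compound 2 lies beyond the scatter in each case. Compound 4 `Cc1ccc(-n2c(C)cc(C(=O)O)c2C)cc1` differs from compound 3 by one change: methyl in place of fluoro on an aromatic carbon. Going by the values given here, no measured pair shows this change, so the expected step from compound 3 to compound 4 is small, likely within the scatter, with no clear direction. The estimated step is a 1.3-fold lower number from compound 3 to compound 4 (0.10 log units; within the scatter). For compound 4 the expected value in this assay is 1500 nM, in a range from 500 nM to 5000 nM.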

Compound 4, half-maximal inhibitory concentration: 2000 nM
For compound 4 the middle estimate is 1.3-fold (0.12 log units) below the measured one, and the stated range covers the measured number.
By their numbers in this assay, from the lowest: compounds 3 and 4 (each within the scatter of the next); then compound 1; then compound 2.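

In this assay, methyl in place of fluoro on an aromatic carbon, para to a large group, gives a 1.1-fold higher number from compound 3 to compound 4 (0.02 log units; within the scatter), so the two groups cannot be told apart at this position. This is the first step shown that differs in one place, and it shows that fluoro is not needed here to keep the value of compound 3. Nothing at hand explains this result. The compounds shown leave open how an amine, a methoxy group or a longer chain would read at this position. They also leave open whether a second group on the same six-membered ring would shift the value.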